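A few compounds are considered here, and "the series" means these few. Any claim that something is new, unique, unknown or untested is made for them only; others in the source may bear on it.

Measured compounds:
- compound 1 `Fc1cccc(F)c1CSc1ccccc1C1=NCCCN1`, in a functional assay on cell membranes for antagonist activity at Melanocortin receptor 4 (Mus musculus), read by radioligand binding (on this read-out lower numbers stand for stronger inhibition and higher numbers for weaker inhibition), compound 1 gives 15800 nM.
- compound 2 `COc1ccc(Br)cc1CCc1ccccc1C1=NCCN1`, in this assay compound 2 gives 39 nM.

Compound 2 holds the lower of the two numbers in this assay; the gap to compound 1 lies beyond the scatter. The two compounds differ in several places at once, so no single change can be read from them.

Compound 3 `COc1ccc(Br)cc1CCc1ccccc1C1=NCCCN1` is not yet measured. It differs from compound 2 by a group of 6 heavy atoms (4 carbon, 2 nitrogen; one six-membered non-aromatic ring with 2 hetero atoms) in place of a group of 5 heavy atoms (3 carbon, 2 nitrogen; one five-membered non-aromatic ring with 2 hetero atoms), on an aromatic carbon. Compound 1 also carries a six-membered ring of this kind, and in this assay compound 1 gives 15800 nM, but its linker and substituents differ as well, so that number is no measure of the ring change alone. A moderate loss is expected, with wide uncertainty. The expected step of a 3.8-fold higher number from compound 2 to compound 3 (0.59 log units; beyond the scatter) leaves compound 3 still well below compound 1. For compound 3 the estimate in this assay is 150 nM, between 30 nM and 1500 nM.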

Compound 3, inhibition constant: 220 nM
Beside the measured number, compound 3's estimate is 1.5-fold (0.17 log units) below it; the range from low to high includes it.
By their numbers in this assay, from the lowest: compound 2; then compound 3; then compound 1.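

Compound 2 and compound 3 differ in one place, so the ring on this aromatic carbon can now be read on its own: in this assay, the six-membered non-aromatic ring with 2 hetero atoms in place of the five-membered one gives a 5.6-fold higher number from compound 2 to compound 3 (0.75 log units; beyond the scatter). This position therefore responds to ring size on the shared core, with the five-membered ring giving the lower number of the two, though the step is modest. Nothing shown accounts for the step.

On these data alone, it remains open how an open-chain amidine or a primary amine would read on this aromatic carbon. Among the compounds shown here, also open is whether the same ring change gives a step of similar size on another linker, such as the one in compound 1.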